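The source may report more compounds than this note shows. Statements on the series, on what has been measured and on what is new or still open speak of the compounds shown alone.

Compound 1 `CN(CC(=O)Nc1nc2ccc(OC(F)(F)F)cc2s1)C(=O)CN` — < 0.1 h
Compound 2 `CNCC(=O)N(C)CC(=O)Nc1nc2ccc(OC(F)(F)F)cc2s1` — < 0.1 h
Compound 3 `CC(C)(NC(=O)CN)C(=O)Nc1nc2ccc(OC(F)(F)F)cc2s1` — 2 h

Among the compounds with values here, in an ADME assay on a cell-free system (serum, Rattus norvegicus) for pharmacokinetics (a lower number here means that the compound disappears faster, a higher number that the compound lasts longer), compound 3 gives 2 h, the only outright number among the three. For compound 1 the value < 0.1 h is a limit of the assay, not a number. For compound 2 the value < 0.1 h is likewise a limit. Compound 3 therefore stands clearly above the other two: the steps of an at least 20-fold higher number from compound 1 to compound 3 (1.30 log units; beyond the scatter) and an at least 20-fold higher number from compound 2 to compound 3 (1.30 log units; beyond the scatter) are both large and beyond the scatter, whereas the step that the two limits leave unreadable from compound 1 to compound 2 cannot be sized because the limit of < 0.1 h in this assay, at which 2 of the 3 values shown sit, hides whatever difference there is between those two.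

Compound 4 `CC(C)(C)NCC(=O)NC(C)(C)C(=O)Nc1nc2ccc(OC(F)(F)F)cc2s1` differs from compound 3 in one place: tert-butyl in place of hydrogen on an amine nitrogen, that is, amino becomes (tert-butyl)amino. Within the data shown here, no measured step bears directly on such a change; the only step on the same kind of nitrogen, a step that the two limits leave unreadable from compound 1 to compound 2, is unreadable. With nothing to point either way, no step beyond the scatter is expected. Compound 4 is estimated at 3 h in this assay, with a range from 1 h to 10 h. That expectation amounts to a 1.5-fold higher number from compound 3 to compound 4 (0.18 log units; within the scatter).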

Compound 4, half-life: > 2 h
Compound 4: no number, only a limit; the forecaster's own chance of this, stated with the estimate: 10%; the middle value does not contradict the limit.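

In this assay compound 4 gives > 2 h, which is a limit of the assay and not a number. Putting tert-butyl on this amine nitrogen, so that amino becomes (tert-butyl)amino, gives a number no lower from compound 3 to compound 4 (the limit leaves the size open); tert-butyl can therefore enter here without the compound disappearing faster. The earlier compounds offered no readable step on an amine nitrogen, and the size of this new step cannot be read either: the limit of > 2 h in this assay, at which 1 of the 4 values shown sits.

On these data alone, what remains open is how long compound 4 actually lasts, and whether a smaller group such as methyl or isopropyl on this same nitrogen would last as long. Also open, as far as these compounds go, is whether a ring such as cyclopropyl or a longer chain such as n-butyl would behave like tert-butyl here.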